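The compounds below may be only part of what the source reports. "The series", "measured", "known", "first", "only" and "open" are said of these compounds alone.

Compound 1 `O=C(Nc1ccc(Sc2nc3ccccc3s2)cc1)c1cc(Br)cc(Br)c1O` — 74000 nM
Compound 2 `COc1ccc(S(=O)(=O)Nc2ccc3oc(-c4ccc(NS(=O)(=O)c5cc(F)ccc5OC)cc4)nc3c2)cc1` — > 100000 nM

Among the compounds with values here, in an ADME assay on FHC cells (Homo sapiens) for cytotoxicity, read by resazurin assay, with a stated time of 48 h (a higher number here means that more compound is tolerated, a lower number that less compound is tolerated), compound 1 gives 74000 nM, the only outright number among the two values. Compound 2 reaches only a limit, > 100000 nM. Compound 1 therefore stands alone as the single figure, with one further value sitting at the limit of > 100000 nM in this assay, at which 1 of the 2 values shown sits. Compound 3 `O=C(Nc1ccc(Sc2nc3ccccc3s2)cc1)c1cccc(Br)c1O` differs from compound 1 by hydrogen in place of bromo on an aromatic carbon. No change between two measured compounds is recorded, so the expectation rests on the structural change itself: in this assay a small step, if any, toward more compound being tolerated. Compound 3 is expected to give about 90000 nM, between 40000 nM and 200000 nM. The estimated step is a 1.2-fold higher number from compound 1 to compound 3 (0.09 log units; within the scatter).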

Compound 3, half-maximal cytotoxic concentration: 59000 nM
Compound 3: the middle estimate sits 1.5-fold (0.18 log units) above what was measured; low and high end bracket the measured number.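

Hydrogen in place of the bromo group para to the hydroxy group gives a 1.3-fold lower number from compound 1 to compound 3 (0.10 log units; within the scatter) in this assay. This first comparison of two compounds differing in one place shows that, for this pair, the assay does not distinguish 3,5-dibromo-2-hydroxyphenyl from 3-bromo-2-hydroxyphenyl. The data shown offer no reason for this result.

From the compounds shown here alone, whether an amine or a carboxylic acid at this position would move the value beyond the scatter remains open. So does the outcome of replacing the remaining bromo group.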